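The compounds below may be only part of what the source reports. "The series", "measured", "known", "first", "only" and "open" are said of these compounds alone.

Compound 1 `C=CCc1ccc(OCc2cn(-c3ccc(OC)cc3)nn2)c(O)c1`: 21.3%
Compound 2 `C=CCc1ccc(OCc2cn(-c3cccc(C#N)c3)nn2)c(O)c1`: 22.5%

In a functional assay on HL-60 cells (Homo sapiens) for inhibition, read by MTT assay, with a stated time of 72 h, tested at 30 uM (a lower number here means less inhibition of growth, a higher number more inhibition of growth at the concentration tested), compound 2 gives 22.5%, and compound 1, at 21.3%, lies within the scatter of it. Compound 3 `C=CCc1ccc(OCc2cn(-c3ccc(Br)cc3)nn2)c(O)c1` has 4-bromophenyl in place of 3-cyanophenyl on an aromatic nitrogen. Going by the values given here, only one measured step bears on this change. It is a number 1.2 percentage points higher from compound 1 to compound 2 (within the scatter), an exchange of one substituted phenyl for another on that same nitrogen, and it stays within the scatter. No step beyond the scatter is therefore expected in this assay. The estimated step is a number 1.5 percentage points higher from compound 2 to compound 3 (within the scatter). For compound 3 the expected value is 24%, with an estimated range of 12% to 37%.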

Compound 3, percent growth inhibition at one concentration: 22.1%
The estimate for compound 3 lay 1.9 percentage points above the measured number; the range from low to high includes it.
By their numbers in this assay, from the lowest: compounds 1, 3 and 2 (each within the scatter of the next).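

In this assay, replacing 3-cyanophenyl with 4-bromophenyl on the aromatic nitrogen gives a number 0.4 percentage points lower from compound 2 to compound 3 (within the scatter) even though the triple bond and the hydrogen-bond acceptor leave with that group. Bromo in place of methoxy on an aromatic carbon gives a number 0.8 percentage points higher from compound 1 to compound 3 (within the scatter) and so does not separate these compounds either. Nothing measured here explains why these three substituted phenyl groups read alike.

From the compounds shown here alone, whether an amine or a carboxylic acid on this phenyl ring would move the number remains open. So does the effect of a longer chain in place of the ring on that nitrogen.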